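This account rests on a few compounds, and the source may have more. Where it says the series, first, only, none or still open, it means among the compounds named here.

Measured in a functional assay on HeLa cells (Homo sapiens) for antiproliferative activity, read by MTT assay, with a stated time of 72 h; a lower number here means a stronger inhibitor, a higher number a weaker inhibitor:
- compound 1 `COc1cc(-n2ncnc2-c2ccc(OC(F)(F)F)cc2)cc(OC)c1OC`: > 10000 nM
- compound 2 `COc1cc(-n2ncnc2-c2ccccc2)cc(OC)c1OC`: > 10000 nM
- compound 3 `COc1cc(-n2ncnc2-c2cccc([N+](=O)[O-])c2)cc(OC)c1OC`: > 10000 nM

Compound 2 has no numerical value, only the limit > 10000 nM. Within the data shown here, the other two entries are also limits, so the series so far rests on (the limit of > 10000 nM in this assay, at which 3 of the 3 values shown sit).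

The next compound is compound 4 `CCOc1ccccc1-c1ncnn1-c1cc(OC)c(OC)c(OC)c1`, which has ethoxy in place of hydrogen on an aromatic carbon, ortho to a large group: ethoxy in place of hydrogen on an aromatic carbon.

Among the measured compounds shown here, two measured steps bear on this change, both also substitutions on an aromatic carbon. The data show a step that the two limits leave unreadable from compound 1 to compound 2 and a step that the two limits leave unreadable from compound 2 to compound 3. For the measured compounds named here, neither gives a size or direction to carry over, so no definite step can be predicted in this assay. The working expectation is that compound 4 stays near the limit of the series, and a report of only a limit is the likeliest outcome.

Compound 4 is estimated at 12000 nM, with an expected range from 3000 nM to 40000 nM.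

The estimate corresponds to an expected step that the limit leaves unreadable from compound 2 to compound 4.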

Compound 4, half-maximal inhibitory concentration: > 10000 nM
Compound 4: only a limit was reported; the forecaster's own chance of this, stated with the estimate: 80%; the middle value lies beyond the limit too.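

No step can be read between compound 2 and compound 4, and the series still rests on a single limit: the limit of > 10000 nM in this assay, at which 4 of the 4 values shown sit.

The compounds shown leave open whether any substituent on the shared core gives a measurable half-maximal inhibitory concentration, and how large a step ethoxy, nitro or trifluoromethoxy makes.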